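The source may hold more compounds than are shown below. What is called first, only, known or untested is meant among the compounds shown, and "the series" means these compounds.

Compound 1 `CCn1cc(-c2ccnc(Nc3ccc(OC)cc3OC)n2)c2ccccc21` is the weakest grower-inhibitor of the three measured compounds in a functional assay on MV4-11 cells (Homo sapiens) for inhibition, read by resazurin assay, with a stated time of 72 h (a lower number here means a stronger inhibitor of growth, a higher number a weaker inhibitor of growth), where compound 1 gives 3590 nM. Among the compounds with values here, compound 2 `CNc1nc(C)c(-c2ccnc(Nc3ccc(OC)cc3OC)n2)s1` gives 300 nM in this assay, and compound 3 `COCCOc1nc(C)c(-c2ccnc(Nc3ccc(OC)cc3OC)n2)s1` gives 1980 nM; the one measured step, a 6.6-fold higher number from compound 2 to compound 3 (0.82 log units; beyond the scatter), concerns a different core. Compound 4 `COc1ccc(Nc2nccc(-c3cn(C(C)C)c4ccccc34)n2)c(OC)c1` differs from compound 1 by methyl in place of hydrogen on a saturated chain carbon bound to an aromatic nitrogen and a saturated chain carbon. Within the data shown here, no measured step touches this part of the core of compound 1, so nothing here argues for a shift in this assay beyond the scatter in either direction. Compound 4 is therefore expected to land close to compound 1, with an estimated step of a 1.0-fold lower number from compound 1 to compound 4 (0.01 log units; within the scatter). The estimate for compound 4 in this assay is 3500 nM, within a range from 1400 nM to 9000 nM.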

Compound 4, concentration for 50% growth inhibition: 3250 nM
Compound 4: the middle estimate sits 1.1-fold (0.03 log units) above what was measured; the measured number falls inside the stated range.
By their numbers in this assay, from the lowest: compound 2; then compounds 3, 4 and 1 (each within the scatter of the next).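

Ethyl to isopropyl gives a 1.1-fold lower number from compound 1 to compound 4 (0.04 log units; within the scatter) in this assay, so the added methyl leaves compound 1 and compound 4 indistinguishable at this position, which no earlier step had touched. This is a single step, and it shows only that this one small enlargement of the chain has no effect that can be told from the scatter. No supporting data bear on the reading of this step. The compounds shown leave open whether a longer chain, or a chain ending in an amine or a carboxylic acid, in place of ethyl would move the number. They also leave open whether removing ethyl altogether, leaving hydrogen, would do so.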